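The compounds below may be only part of what the source reports. "The series", "measured", "known", "first", "only" and "open" are said of these compounds alone.

Compound 1 `COc1cc2c(cc1CC=C(C)C)C(=O)C[C@@H](c1ccc(Oc3ccccc3)cc1)O2` was tested in a functional assay on PC-3 cells (Homo sapiens) for inhibition, read by sulforhodamine B assay, with a stated time of 48 h, tested at 50 uM (on this read-out lower numbers stand for less inhibition of growth and higher numbers for more inhibition of growth at the one concentration tested), where compound 1 gives 53%. Among the compounds with values here, only one other compound has been measured alongside it: compound 2 `COc1ccc([C@@H]2C/C(=N/OCc3cn(-c4ccc(O)cc4)nn3)c3cc(CC=C(C)C)c(OC)cc3O2)cc1`, which in this assay reaches 64%. Of these two numbers compound 1 is the lower one, and the gap to compound 2 is wider than the usual scatter of such measurements, so compound 1 is the weaker grower-inhibitor of the pair. Nothing more can be said of a trend from two compounds alone.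

The next compound, compound 3 `C#CCOc1ccc([C@@H]2CC(=O)c3cc(CC=C(C)C)c(OC)cc3O2)cc1`, keeps the core of compound 1 and changes a single place: propargyl in place of phenyl on an oxygen on an aromatic ring. Cut one bond further out, the change reads phenoxy to propargyloxy. Within the data shown here, no measured pair shows what this kind of swap does here, so the expected step rests only on the size of the change: a ring of six carbon atoms gives way to a three-carbon chain with a triple bond. In this assay the step of a number 9 percentage points lower from compound 1 to compound 3 (within the scatter) is expected to be a modest loss, close to the edge of the scatter. Compound 3 is therefore estimated at 44%, within a range from 25% to 63%.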

Compound 3, percent growth inhibition at one concentration: 52%
Compound 3: the middle estimate sits 8 percentage points below what was measured; low and high end bracket the measured number.
By their numbers in this assay, from the lowest: compounds 3 and 1 (each within the scatter of the next); then compound 2.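

Within the data shown here, putting propargyl in place of phenyl on this oxygen on an aromatic ring gives a number 1 percentage points lower from compound 1 to compound 3 (within the scatter) in this assay, the first direct look at what this position tolerates. A six-membered aromatic ring and a much shorter chain with a triple bond cannot be told apart on this read-out, so for this pair the inhibition of growth at the one concentration tested does not depend on keeping the outer phenyl ring. No measurement is at hand to explain why the two groups read alike.

Going by these compounds, with only phenyl and propargyl seen on this oxygen, it remains open whether the triple bond matters at all, and a plain propyl chain, a longer chain such as a hexyl chain, or a chain ending in an amine or a carboxylic acid could each test how much variety the position accepts. A single concentration also leaves open whether compound 1 and compound 3 would still read alike across a range of concentrations, where a difference hidden at one test point might appear.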